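Swapping an amide for an amine on the saturated ring nitrogen

The compounds below may be only part of what the source reports. "The series", "measured", "known", "first", "only" and "open" are said of these compounds alone.

Compound 3 `O=C(NC1Cc2ccc(NC(=O)c3ccccc3-c3ccc(C(F)(F)F)cc3)cc2C1)c1ccccc1` gives 270 nM in an assay for inhibition of apolipoprotein B-100 (Homo sapiens), tested at 100 nM (on this read-out lower numbers stand for stronger inhibition and higher numbers for weaker inhibition), the highest of the three numbers shown. Compound 2 `CS(=O)(=O)NC1Cc2ccc(NC(=O)c3ccccc3-c3ccc(C(F)(F)F)cc3)cc2C1` gives 60 nM, and compound 1 `Cc1cccc(C(=O)Nc2ccc3c(c2)CC(NS(=O)(=O)c2ccccc2)C3)c1-c1ccc(F)cc1` gives 1.2 nM. Compound 4 `O=C(Nc1ccc2c(c1)CC(NCc1ccccc1)C2)c1ccccc1-c1ccc(C(F)(F)F)cc1` differs from compound 3 by benzyl in place of benzoyl on an amine nitrogen. Within the data shown here, the one measured step at this nitrogen, a 4.5-fold higher number from compound 2 to compound 3 (0.65 log units; beyond the scatter), shows that changes here move the number beyond the scatter, but no measured pair exchanges a benzoyl for a benzyl, so the direction is uncertain. Given that compound 3 already sits at the weak end, compound 4 is expected to land near it or somewhat weaker, a step of a 2.2-fold higher number from compound 3 to compound 4 (0.35 log units; beyond the scatter), with an estimate of 600 nM, ranging from 150 nM to 2500 nM.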

Compound 4, half-maximal inhibitory concentration: 340 nM
Compound 4: middle estimate off by 1.8-fold (0.25 log units), on the high side; the range from low to high includes it.
By their numbers in this assay, from the lowest: compound 1; then compound 2; then compounds 3 and 4 (each within the scatter of the next).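

Benzyl in place of benzoyl on this amine nitrogen gives a 1.3-fold higher number from compound 3 to compound 4 (0.10 log units; within the scatter) in this assay and so the two groups cannot be told apart here, although benzyl has no carbonyl. Benzyl in place of methylsulfonyl gives a 5.7-fold higher number from compound 2 to compound 4 (0.75 log units; beyond the scatter) and this matches the direction already seen with benzoyl, so among these three groups methylsulfonyl alone stands apart. From the compounds shown here alone, whether an acetyl group or a bare amine on this nitrogen would fall with methylsulfonyl or with the other two stays open. Nothing measured here gives a reason for these steps.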